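The compounds below may be only part of what the source reports. "The series", "measured", "known", "first", "only" and "open" are said of these compounds alone.

Going by the values given here, in a functional assay on aorta for antagonist activity at Alpha-1D adrenergic receptor (Rattus norvegicus) (a higher number here means weaker binding, a lower number tighter binding), compound 3 `CN(C)C(=O)c1cccnc1NCCCN1CCN(c2ccccc2C#N)CC1` gives 10 nM, the lowest of the three numbers measured so far; the nearest is compound 2 `CN(C)C(=O)c1cccnc1NCCCN1CCN(c2ccccc2)CC1` with 15.9 nM, and the furthest is compound 1 `COc1ccccc1N1CCN(CCCNc2ncc(C#N)cc2C(=O)N(C)C)CC1` with 20 nM, and both of these gaps lie within the scatter. Among the compounds with values here, the only step between two compounds that differ in a single place, a 1.6-fold lower number from compound 2 to compound 3 (0.20 log units; within the scatter), is also within the scatter. Compound 4 `CCOc1ccccc1N1CCN(CCCNc2ncccc2C(=O)N(C)C)CC1` differs from compound 3 in one place: ethoxy in place of cyano on an aromatic carbon. Within the data shown here, no measured step exchanges a cyano for an ethoxy, so the step from compound 2 to compound 3 is the only one that bears on it, and it shows that putting the cyano on that aromatic carbon changed nothing beyond the scatter; taking it away again and placing ethoxy there is therefore expected to move the number only a little. For compound 4 the expected step is a 1.5-fold higher number from compound 3 to compound 4 (0.18 log units; within the scatter). Compound 4 is estimated at 15 nM in this assay, with a range from 5 nM to 45 nM.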

Compound 4, dissociation constant: 7.94 nM
For compound 4 the middle estimate is 1.9-fold (0.28 log units) above the measured one, and the stated range covers the measured number.
By their numbers in this assay, from the lowest: compounds 4, 3, 2 and 1 (each within the scatter of the next, the first and the last beyond it).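

Until now this position, on an aromatic carbon ortho to a large group, had been compared only between hydrogen and cyano; ethoxy adds a third group, with 3 heavy atoms where cyano has 2. In this assay the exchange of cyano for ethoxy gives a 1.3-fold lower number from compound 3 to compound 4 (0.10 log units; within the scatter) and the exchange of hydrogen for ethoxy gives a 2.0-fold lower number from compound 2 to compound 4 (0.30 log units; within the scatter), so compound 2, compound 3 and compound 4 cannot be told apart here, and this position has tolerated all three groups so far. Nothing available explains why these three groups give such similar numbers.

From the compounds shown here alone, what an amine or a carboxylic acid would do at this position remains open. So does a longer chain such as butoxy, which would show whether this tolerance extends to larger groups.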